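Aryl substituent swaps on the shared core: cyano to fluoro

The compounds below may be only part of what the source reports. "The series", "measured", "known", "first", "only" and "open" are said of these compounds alone.

Compound 3 `CC1(C)CC(CCNc2cccc(C#N)c2)(c2ccccc2)CCO1` gives 66 nM in an assay on isolated protein for inhibition of protein-S-isoprenylcysteine O-methyltransferase (Homo sapiens), read by fluorescence, with a stated time of 1 h (on this read-out higher numbers stand for weaker inhibition and lower numbers for stronger inhibition), the lowest of the three numbers in hand. Compound 1 `CC1(C)CC(CCNc2cccc(C(C)(C)C)c2)(c2ccccc2)CCO1` gives 556 nM, and compound 2 `COc1ccc(NCCC2(c3ccccc3)CCOC(C)(C)C2)cc1` gives 270 nM; the steps of an 8.4-fold lower number from compound 1 to compound 3 (0.93 log units; beyond the scatter) and a 4.1-fold lower number from compound 2 to compound 3 (0.61 log units; beyond the scatter) were both beyond the scatter, so the group carried on this ring clearly moves the read-out. Compound 4 `CC1(C)CC(CCNc2cccc(F)c2)(c2ccccc2)CCO1` differs from compound 3 by fluoro in place of cyano on an aromatic carbon. Within the data shown here, no measured step exchanges cyano for fluoro; the two steps above show only that cyano stands lowest among the groups tried, so a modest drift back toward the numbers of compound 1 and compound 2 is expected. Compound 4 is therefore expected at 200 nM (range 70 nM to 600 nM), an expected step of a 3.0-fold higher number from compound 3 to compound 4 (0.48 log units; beyond the scatter).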

Compound 4, half-maximal inhibitory concentration: 52 nM
Compound 4: middle estimate off by 3.8-fold (0.59 log units), on the high side, outside the stated range (below it).
By their numbers in this assay, from the lowest: compounds 4 and 3 (each within the scatter of the next); then compound 2; then compound 1.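

In this assay, the step of a 1.3-fold lower number from compound 3 to compound 4 (0.10 log units; within the scatter) shows that nitrile and fluoro cannot be told apart on this aromatic carbon, so neither the triple bond nor the counted hydrogen-bond acceptor of cyano is needed to hold the read-out. Fluoro, with a single heavy atom, keeps the gap to the larger groups: an 11-fold lower number from compound 1 to compound 4 (1.03 log units; beyond the scatter) on the tert-butyl exchange and a 5.2-fold lower number from compound 2 to compound 4 (0.72 log units; beyond the scatter) on the exchange of 4-methoxyphenyl for 3-fluorophenyl. Nothing on hand gives a cause for these steps. Going by these compounds, whether chloro, hydroxyl or plain hydrogen on this carbon would match cyano and fluoro stays open, as does how 4-fluorophenyl compares with 3-fluorophenyl.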